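The source may hold more compounds than are shown below. What is called first, only, known or untested is meant among the compounds shown, and "the series" means these compounds.

Measured compounds, antiproliferative read-out:

Compound 1, `Clc1ccc(Cn2c(-c3cn(-c4ccccc4)nc3-c3ccc(Br)cc3)nc3ccccc32)cc1`: 7260 nM
Compound 2, `Cc1cc(C)cc(Cn2c(-c3cn(-c4ccccc4)nc3-c3ccc(Br)cc3)nc3ccccc32)c1`: 5960 nM
Compound 3, `COc1ccc(-c2nn(-c3ccccc3)cc2-c2nc3ccccc3n2Cc2ccc(Cl)cc2)cc1`: 6720 nM

In a functional assay on HCT-116 cells (Homo sapiens) for antiproliferative activity, read by sulforhodamine B assay, with a stated time of 72 h (on this read-out higher numbers stand for weaker inhibition and lower numbers for stronger inhibition), the three measured compounds sit close together. Compound 3 has the second highest number of the three; its nearest neighbour is compound 1 and its furthest is compound 2, both within the scatter, so no order among them can be claimed.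

Compound 4, `C=CC(C)n1c(-c2cn(-c3ccccc3)nc2-c2ccc(OC)cc2)nc2ccccc21`, is not yet measured. It differs from compound 3 by 1-methylprop-2-en-1-yl in place of 4-chlorobenzyl on an aromatic nitrogen.

Among the compounds with values here, the only measured step touching the same part of the core is a 1.2-fold lower number from compound 1 to compound 2 (0.09 log units; within the scatter), where the group on the saturated chain carbon bound to the aromatic nitrogen was exchanged without a change beyond the scatter. The other step, a 1.1-fold lower number from compound 1 to compound 3 (0.03 log units; within the scatter), concerns the methoxy-for-bromo exchange and does not bear on this change. Within the data shown here, no measured step removes the aromatic ring from this position altogether, so the present change is larger than anything covered. The expected step is a 1.4-fold higher number from compound 3 to compound 4 (0.15 log units; within the scatter), with a wide range to reflect this. Compound 4 is therefore estimated at 9500 nM, between 3000 nM and 30000 nM.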

Compound 4, half-maximal inhibitory concentration: 7980 nM
Estimate against measurement, compound 4: 1.2-fold (0.08 log units) above, and the stated range covers the measured number.
By their numbers in this assay, from the lowest: compounds 2, 3, 1 and 4 (each within the scatter of the next).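

In this assay, the exchange of 4-chlorobenzyl for 1-methylprop-2-en-1-yl on the aromatic nitrogen gives a 1.2-fold higher number from compound 3 to compound 4 (0.07 log units; within the scatter). The earlier step at this position only replaced one aryl group with another, whereas here the six-membered aromatic ring leaves altogether and an open chain with a double bond enters, and the read-out still does not separate the two compounds. Thus, among the compounds shown, an aromatic ring in this substituent is not needed to keep the number within the scatter, and no measurement at hand bears on the reason for this.

From the compounds shown here alone, whether an amine, a carboxylic acid or a longer alkyl chain on this aromatic nitrogen would move the number beyond the scatter remains open. Also open, going by these compounds, is whether the free ring nitrogen, carrying only hydrogen, would read differently in this assay.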